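The source may report more compounds than this note shows. Statements on the series, on what has been measured and on what is new or still open speak of the compounds shown alone.

Measured so far in a functional assay on BT-549 cells (Homo sapiens) for antiproliferative activity, with a stated time of 48 h; on this read-out higher numbers stand for lower toxicity in this test and lower numbers for higher toxicity in this test:
compound 1 `Cc1cc(O)c(C2=NN(c3ccc(S(N)(=O)=O)cc3)C(c3ccccc3O)C2)cc1Cl` 58700 nM
compound 2 `Cc1cc(O)c(C2=NN(c3ccc(S(N)(=O)=O)cc3)C(c3ccccc3Cl)C2)cc1Cl` 18300 nM
compound 3 `Cc1cc(O)c(C2=NN(c3ccc(S(N)(=O)=O)cc3)C(/C=C/c3ccccc3)C2)cc1Cl` 54500 nM

Compound 3 stands second highest of the three; its number sits within the scatter of compound 1 and is a 3.0-fold higher number from compound 2 to compound 3 (0.47 log units; beyond the scatter). Compound 4 `COc1ccc(C2CC(c3cc(Cl)c(C)cc3O)=NN2c2ccc(S(N)(=O)=O)cc2)cc1OC` differs from compound 3 in one place: 3,4-dimethoxyphenyl in place of 2-phenylethenyl on a saturated ring carbon. For the measured compounds named here, two measured steps touch the same saturated ring carbon: a 1.1-fold lower number from compound 1 to compound 3 (0.03 log units; within the scatter) and a 3.0-fold higher number from compound 2 to compound 3 (0.47 log units; beyond the scatter). Replacing the group at that carbon has therefore moved this assay either not beyond the scatter or modestly. An aryl group with two acceptors has not been tried here, so the direction is open; a step of modest size or none is expected, a 1.4-fold lower number from compound 3 to compound 4 (0.13 log units; within the scatter). Compound 4 is estimated at 40000 nM, within 12000 nM to 90000 nM.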

Compound 4, concentration lethal to 50% of the cells: 95600 nM
The estimate for compound 4 lay 2.4-fold (0.38 log units) below the measured number; measured number above the stated range.
By their numbers in this assay, from the lowest: compound 2; then compounds 3, 1 and 4 (each within the scatter of the next).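

In this assay, 3,4-dimethoxyphenyl on this saturated ring carbon gives a 1.8-fold higher number from compound 3 to compound 4 (0.24 log units; within the scatter) and a 1.6-fold higher number from compound 1 to compound 4 (0.21 log units; within the scatter) and so cannot be told apart from 2-phenylethenyl or 2-hydroxyphenyl. Only the 2-chlorophenyl compound stands apart, with a 5.2-fold higher number from compound 2 to compound 4 (0.72 log units; beyond the scatter) as the widest step yet seen at this position, though still modest. Nothing available explains this difference.

Going by these compounds, whether the chlorine itself sets compound 2 apart remains open. So does how an amine or a carboxylic acid on this aryl group, or a longer alkyl chain at this carbon, would read.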